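This account rests on a few compounds, and the source may have more. Where it says the series, first, only, none or still open, it means among the compounds named here.

The series shares one core, shown for compound 1 as `Cc1ccc(S(=O)(=O)NCc2cn(Cc3cc(=O)oc4cc(O)ccc34)nn2)cc1`, and compound 2, `O=c1cc(Cn2cc(CNS(=O)(=O)c3ccc(Cl)cc3)nn2)c2ccc(O)cc2o1`, and compound 3, `O=c1cc(Cn2cc(CNS(=O)(=O)c3ccc(F)cc3)nn2)c2ccc(O)cc2o1`, differ from it only in one aromatic substituent. In a functional assay on SW-620 cells (Homo sapiens) for inhibition, read by MTT assay, with a stated time of 72 h (on this read-out lower numbers stand for stronger inhibition and higher numbers for weaker inhibition), compound 1 gives 92200 nM. Compound 2 reaches only the assay limit in this assay, > 100000 nM. Compound 3 likewise stops at the limit in this assay, > 100000 nM, so compound 3 stands at a limit rather than at a number, sharing (the limit of > 100000 nM in this assay, at which 2 of the 3 values shown sit). The step of an at least 1.0-fold higher number from compound 1 to compound 2 (0.03 log units; that floor lies within the scatter) and the step of an at least 1.0-fold higher number from compound 1 to compound 3 (0.03 log units; that floor lies within the scatter) show only a floor, and the step that the two limits leave unreadable from compound 2 to compound 3 cannot be read. Compound 4, `O=c1cc(Cn2cc(CNS(=O)(=O)c3ccc(F)cc3Cl)nn2)c2ccc(O)cc2o1`, differs from compound 3 by chloro in place of hydrogen on an aromatic carbon. Among the compounds with values here, no measured step mirrors this change, and every step that exists points toward the limit. Compound 4 is expected to show a number no higher from compound 3 to compound 4 (the limit leaves the size open). Compound 4 is estimated to give 100000 nM in this assay, within a range from 50000 nM to 200000 nM.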

Compound 4, half-maximal inhibitory concentration: > 100000 nM
Compound 4 ended at the assay's limit; the forecaster's own chance of this, stated with the estimate: 70%; the middle value sits exactly at the limit.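

With chloro ortho to a large group, compound 4 stays at the limit in this assay, so the 2-chloro-4-fluorophenyl group now joins the 4-chlorophenyl and 4-fluorophenyl groups there. The steps to compound 4 from the other two compounds at the limit cannot be read, and the only readable one is an at least 1.0-fold higher number from compound 1 to compound 4 (0.03 log units; that floor lies within the scatter), which gives a floor and no size. Only compound 1 keeps a number, and the limit now holds most of the series: the limit of > 100000 nM in this assay, at which 3 of the 4 values shown sit.

As far as these compounds go, whether any change on this ring can give a clear number below the limit remains open. An amine or a carboxylic acid on the ring, or a longer chain in place of the ring, could speak to that.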